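Removing a Single Fluorine from a Potent Amidase Inhibitor

The source may report more compounds than this note shows. Statements on the series, on what has been measured and on what is new or still open speak of the compounds shown alone.

Of the compounds shown here, two have been measured in an assay on isolated protein for inhibition of N-acylethanolamine-hydrolyzing acid amidase (Homo sapiens), read by fluorescence, with a stated time of 90 min (a lower number here means a stronger inhibitor, a higher number a weaker inhibitor), so far. Compound 1 `COc1ccc(-c2ccc(S(=O)(=O)N[C@H]3C[C@@H](N=C=S)C3)cc2)cc1F` stands at the lowest number of the two: in this assay compound 1 gives 3.2 nM. Compound 2 `COc1ccc(C2CC(C(=O)N[C@H]3C[C@@H](N=C=S)C3)C2)cc1` is built on a different core, and in this assay compound 2 gives 55.9 nM, a number that lies far above that of compound 1, well beyond the scatter. For the measured compounds named here, no pair of measured compounds differs in only one place, so there is no measured step to serve as a direct precedent.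

Compound 3 `COc1ccc(-c2ccc(S(=O)(=O)N[C@H]3C[C@@H](N=C=S)C3)cc2)cc1` differs from compound 1 in one place: hydrogen in place of fluoro on an aromatic carbon. Everything else in the structure, including the methoxy group and the rest of the shared core, is retained. Because compound 1 gives 3.2 nM, the starting point is already strong, and the loss of one fluorine is a small structural change. The step is expected to be a 1.9-fold higher number from compound 1 to compound 3 (0.27 log units; within the scatter), small, and if it reaches beyond the scatter at all, more likely toward a somewhat weaker inhibitor. Compound 3 is therefore expected to give 6 nM, within a range from 1.5 nM to 25 nM.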

Compound 3, half-maximal inhibitory concentration: 2.3 nM
Compound 3: the middle estimate sits 2.6-fold (0.42 log units) above what was measured; measured number inside the range.
By their numbers in this assay, from the lowest: compounds 3 and 1 (each within the scatter of the next); then compound 2.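

For the compounds shown here, the one step between compounds that differ in a single place, a 1.4-fold lower number from compound 1 to compound 3 (0.14 log units; within the scatter), shows that in this assay hydrogen can stand in place of fluoro on this aromatic carbon, ortho to a methoxy group, without a difference that can be told from the scatter of repeated measurements. This is something the earlier comparison of compound 1 and compound 2 could not show, since those two differ in more than one place; here the methoxy group and the rest of the structure stay the same, and the fluorine proves unnecessary for a low number in this assay. No measurement shown here bears on why the two compounds read alike.

Whether this aromatic carbon accepts anything larger remains open, since the compounds shown carry only hydrogen or fluoro there, and a chlorine, a methyl group, a trifluoromethyl group or an amine could give a quite different number. On these data alone, the role of the methoxy group itself is also open, and exchanging it for a hydroxyl group or a longer ethoxy chain would be a separate question.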